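The compounds below may be only part of what the source reports. "The series", "measured", "known", "first", "only" and "open" are said of these compounds alone.

Compound 1, whose structure is `N#Cc1c(Cn2c(=O)n(C3CC3)c3ccncc32)nc2cc(Cl)ccn12`, is the reference point of this small set. For the measured compounds named here, in an ADME assay on HEp-2 cells (Homo sapiens) for cytotoxicity, read by CCK-8 assay, with a stated time of 6 days (a higher number here means that more compound is tolerated, a lower number that less compound is tolerated), compound 1 gives 22500 nM, and this is the only actual number in the set. Compound 2, `O=C(CCc1c(Cn2c(=O)n(C3CC3)c3ccncc32)nc2cc(Cl)ccn12)NCCO`, carries a 2-((2-hydroxyethyl)carbamoyl)ethyl group where compound 1 carries cyano. In this assay compound 2 reaches only the limit > 100000 nM, which is a limit of the assay rather than a number. That single measured step, an at least 4.4-fold higher number from compound 1 to compound 2 (0.64 log units; beyond the scatter), is the one that bears on the change under discussion, and it sits on (the limit of > 100000 nM in this assay, at which 1 of the 2 values shown sits).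

Compound 3, `CS(=O)(=O)c1ccc(-c2c(Cn3c(=O)n(C4CC4)c4ccncc43)nc3cc(Cl)ccn23)cc1`, differs from compound 1 by 4-(methylsulfonyl)phenyl in place of cyano on an aromatic carbon. As with compound 2, the cyano group is replaced by a larger substituent, so the measured step points toward a higher number, though its true size is hidden by the limit and the entering group is of a different kind. Compound 3 is therefore expected to be tolerated somewhat better than compound 1, with an estimated step of a 2.0-fold higher number from compound 1 to compound 3 (0.30 log units; within the scatter). The estimate for compound 3 in this assay is 45000 nM, within a range from 15000 nM to 150000 nM.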

Compound 3, half-maximal cytotoxic concentration: > 100000 nM
Compound 3: no number, only a limit; the forecaster's own chance of this, stated with the estimate: 40%; at least 2.2-fold (0.34 log units) between middle value and limit.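

At the aromatic carbon that carries cyano in compound 1, a second and quite different replacement now gives a step of the same reach in this assay: an at least 4.4-fold higher number from compound 1 to compound 3 (0.64 log units; beyond the scatter). The rise seen with compound 2 is therefore not tied to the 2-((2-hydroxyethyl)carbamoyl)ethyl chain, since 4-(methylsulfonyl)phenyl, with its six-membered aromatic ring of carbon only and 0 hydrogen-bond donors, also takes the number beyond the scatter. Compound 2 and compound 3 both stand at a limit of the assay rather than at a number, so the step between them cannot be read and the two replacements cannot be ranked: the limit of > 100000 nM in this assay, at which 2 of the 3 values shown sit.

Going by these compounds, how far above compound 1 either replacement truly lies remains open, and so does whether the rise depends on the number of heavy atoms entering at this carbon. Also open, on these data alone, is whether a methyl, a primary amide or an unsubstituted phenyl in the same place would move the number away from that of compound 1, and whether an amine or a carboxylic acid at the end of the chain would behave like the hydroxyethyl amide.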